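Trading a Lactone Ring for a Dioxolane Tail

This account rests on a few compounds, and the source may have more. Where it says the series, first, only, none or still open, it means among the compounds named here.

Two compounds share a core and differ only in the tail carried on the saturated chain carbon bound to a sulfur. Compound 1 `C[C@@]1(O)CC(=O)OC(CSc2nc(-c3ccccc3)c(-c3ccccc3)[nH]2)C1` is measured in an assay on microsomes from liver for inhibition of sterol O-acyltransferase 1 (Rattus norvegicus) (a higher number here means a weaker inhibitor, a lower number a stronger inhibitor), at 170 nM, the higher of the two numbers recorded. Compound 2 `C[C@@]1(O)CC(=O)OC(CSc2nc(-c3cccc(Cl)c3)c(-c3cccc(Cl)c3)[nH]2)C1` gives 110 nM in this assay, a difference from compound 1 that stays within the usual scatter, so the two cannot be ranked against each other.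

Compound 3 `c1ccc(-c2nc(SCC3OCCO3)[nH]c2-c2ccccc2)cc1` has not yet been measured. Relative to compound 1 it carries a smaller tail: a group of 5 heavy atoms (3 carbon, 2 oxygen; one five-membered non-aromatic ring with 2 hetero atoms) in place of a group of 9 heavy atoms (6 carbon, 3 oxygen; one six-membered non-aromatic ring with 1 hetero atom), on a saturated chain carbon bound to a sulfur. For the measured compounds named here, the tail that enters is a 1,3-dioxolan-2-yl, while the group that leaves includes the single hydrogen-bond donor of compound 1.

Going by the values given here, no measured pair shows such a step, so the expectation rests on the structural change alone. The step of a 2.6-fold higher number from compound 1 to compound 3 (0.42 log units; beyond the scatter) is expected to lie toward weaker inhibition, likely beyond the scatter. Compound 3 is estimated at 450 nM in this assay, within a range from 120 nM to 1800 nM.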

Compound 3, half-maximal inhibitory concentration: 530 nM
Estimate against measurement, compound 3: 1.2-fold (0.07 log units) below; the range from low to high includes it.
By their numbers in this assay, from the lowest: compounds 2 and 1 (each within the scatter of the next); then compound 3.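

Compounds 1 and 2 carry the same six-membered ring tail, so they could say nothing about this position. Compound 3 shows that the tail on the saturated chain carbon bound to a sulfur does matter: replacing it with the smaller 1,3-dioxolan-2-yl gives a 3.1-fold higher number from compound 1 to compound 3 (0.49 log units; beyond the scatter) in this assay, a modest loss of inhibition rather than a complete one. Nothing available explains why the number rises.

This single step changes the ring size, the heavy-atom count and the hydrogen-bond donor together, so the part of the old tail that counts cannot be singled out. From the compounds shown here alone, whether a short chain ending in a hydroxyl group or a carboxylic acid at this place would behave more like compound 1 remains open.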